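This account rests on a few compounds, and the source may have more. Where it says the series, first, only, none or still open, it means among the compounds named here.

Of the compounds shown here, three sharing one core have been measured in an assay on isolated protein for inhibition of Dihydrofolate reductase (Mus musculus); a lower number here means a less potent compound, a higher number a more potent compound, by a factor of ten per unit of this negative logarithm. Compound 1, `CC1(C)N=C(N)N=C(N)N1c1ccc(OCCCC(=O)Nc2cccc(S(=O)(=O)F)c2)c(Cl)c1`, gives 7.17. Compound 2, `CN(C(=O)COc1ccc(N2C(N)=NC(N)=NC2(C)C)cc1Cl)c1ccc(S(=O)(=O)F)cc1`, gives 7.47. Compound 3, `CC(Oc1ccc(N2C(N)=NC(N)=NC2(C)C)cc1Cl)C(=O)Nc1ccc(S(=O)(=O)F)cc1`, gives 7.13. On these numbers compound 1 sits close to both companions: compound 3 lies nearest, and even compound 2, the furthest of the two, differs from it by an amount that falls within the usual scatter of repeated measurements. Within the data shown here, no pair among the three, therefore, can be said to differ in any real sense, and no step between single-point changes is available from them.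

Compound 4, `CC1(C)N=C(N)N=C(N)N1c1ccc(OCCCC(=O)Nc2ccc(S(=O)(=O)F)cc2)c(Cl)c1`, has not yet been measured. It has the same atoms as compound 1, joined differently, and the change is 4-(fluorosulfonyl)phenyl in place of 3-(fluorosulfonyl)phenyl on an amide-type nitrogen. Compounds 2 and 3 already carry the 4-(fluorosulfonyl)phenyl group on their amide-type nitrogen, and their values in this assay lie within the scatter of compound 1, so nothing in the data points to a move beyond the scatter in either direction. The step from compound 1 to compound 4 is accordingly expected to be small, a number 0.08 log units higher from compound 1 to compound 4 (within the scatter). Compound 4 is estimated at 7.25, within a range from 6.75 to 7.75.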

Compound 4, logarithm of the reciprocal of the active concentration, log(1/C): 7.15
Compound 4: the middle estimate sits 0.10 log units above what was measured; the range from low to high includes it.
By their numbers in this assay, from the lowest: compounds 3, 4, 1 and 2 (each within the scatter of the next, the first and the last beyond it).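

In this assay, among these compounds, placing 4-(fluorosulfonyl)phenyl instead of 3-(fluorosulfonyl)phenyl on the amide-type nitrogen gives a number 0.02 log units lower from compound 1 to compound 4 (within the scatter) and so provides the first comparison in this set that isolates one change. Among the compounds shown here, with the rest of the molecule held constant, this assay does not separate the two groups at this place, something the earlier compounds could not show, as no two of them differed in one place only. Nothing available here explains why the two groups read alike.

From the compounds shown here alone, this finding rests on a single pair, and whether the same exchange would also read alike on the chains of compound 2 and compound 3 remains open. The compounds shown also leave open how far this place tolerates other groups, such as an unsubstituted phenyl, or an amine or a carboxylic acid in place of the fluorosulfonyl group.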